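Compound 4 and the Cytotoxicity Limit

This account rests on a few compounds, and the source may have more. Where it says the series, first, only, none or still open, it means among the compounds named here.

Compounds measured so far in an ADME assay on HEK293 cells (Homo sapiens) for cytotoxicity, with a stated time of 72 h (a lower number here means that less compound is needed, a higher number that more compound is needed for the effect), each reported only as a limit of the assay:
- compound 1 `C=C[C@@](C)(/C=C/c1ccc(OCc2ccccc2)cc1)CCC=C(C)C` gives > 36600 nM (a limit)
- compound 2 `C=C[C@@](C)(/C=C/c1ccc(O)c(C=O)c1)CCC=C(C)C` gives > 36600 nM (a limit)
- compound 3 `C=C[C@@](C)(/C=C/c1ccc(O)c(/C=C/C(=O)OCc2ccccc2)c1)CCC=C(C)C` gives > 36600 nM (a limit)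

Compound 3 has no exact value in this assay, only a limit (> 36600 nM) and nothing finer. It is not alone, as the whole set so far comes down to the limit of > 36600 nM in this assay, at which 3 of the 3 values shown sit, and offers no exact number to compare.

Compound 4 `C=C[C@@](C)(/C=C/c1ccc(O)c(/C=C/c2ccc(Cl)cc2)c1)CCC=C(C)C` keeps the shared core of compound 3 but exchanges one group (4-chlorophenyl in place of benzyloxycarbonyl on a double-bonded chain carbon bound to a double-bonded chain carbon) on a double-bonded chain carbon bound to a double-bonded chain carbon. In plain words, 4-chlorophenyl stands in place of benzyloxycarbonyl.

Among the measured compounds shown here, no two measured compounds differ in just one place, so the data give no direct measure of what such a swap does. The expectation is therefore no change beyond the scatter, resting on the limit of compound 3 (> 36600 nM) as the only anchor. The expected step is a number no higher from compound 3 to compound 4 (the limit leaves the size open), and any real shift would be expected toward a lower number.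

Compound 4 is estimated at 36600 nM, with an expected range from 14000 nM to 50000 nM.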

Compound 4, half-maximal effective concentration: > 36600 nM
Compound 4: only a limit was reported; the forecaster's own chance of this, stated with the estimate: 70%; the middle value lies on the limit itself.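

In this assay compound 4 gives > 36600 nM, which is a limit and not an exact number. The steps from compound 2 and from compound 3 to compound 4 cannot be read, because every value rests on the same limit: the limit of > 36600 nM in this assay, at which 4 of the 4 values shown sit.

The compounds shown leave open what exact concentration any of them needs, and whether 4-chlorophenyl in place of benzyloxycarbonyl changes it at all.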